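Swapping the Amide Tail of a Diacylthioglycerol Lipopeptide

The compounds below may be only part of what the source reports. "The series", "measured", "known", "first", "only" and "open" are said of these compounds alone.

Measured so far:
compound 1, `CCCCCCCCCCCC(=O)OC[C@H](CSC[C@@H](N)C(=O)N[C@@H](C)CO)OC(=O)CCCCCCCCCCC`, 1560 nM
compound 2, `CCCCCCCCCCCC(=O)OC[C@H](CSC[C@@H](N)C(=O)NCCOCCOS(=O)(=O)O)OC(=O)CCCCCCCCCCC`, 61 nM

In an assay on HEK293 cells for agonist activity at Toll-like receptor 2 (Homo sapiens) (on this read-out higher numbers stand for an effect only at larger amounts of compound and lower numbers for an effect already at smaller amounts), compound 2 gives 61 nM, the lowest of the two numbers; its nearest neighbour is compound 1, whose number is higher by a 26-fold lower number from compound 1 to compound 2 (1.41 log units; beyond the scatter). Compound 3, `CCCCCCCCCCCC(=O)OC[C@H](CSC[C@@H](N)C(=O)NCCCCCC(=O)O)OC(=O)CCCCCCCCCCC`, has not yet been measured in this assay. It differs from compound 2 by 3-carboxypropyl in place of 2-(sulfooxy)ethoxy on a saturated chain carbon, two bonds along the chain from an amide-type nitrogen. For the measured compounds named here, the only measured step that bears on this change is the one on the same amide-type nitrogen, where the swap of tail gave a 26-fold lower number from compound 1 to compound 2 (1.41 log units; beyond the scatter), a large movement. That step shows the tail can matter greatly, but it does not tell how a 3-carboxypropyl tail compares with a 2-(sulfooxy)ethoxy tail. Compound 3 is therefore expected to sit between the two measured values, at 200 nM (range 50 nM to 800 nM). This amounts to an expected step of a 3.3-fold higher number from compound 2 to compound 3 (0.52 log units; beyond the scatter) in this assay.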

Compound 3, half-maximal effective concentration: 108 nM
The estimate for compound 3 lay 1.9-fold (0.27 log units) above the measured number; measured number inside the range.
By their numbers in this assay, from the lowest: compounds 2 and 3 (each within the scatter of the next); then compound 1.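

In this assay, the step of a 1.8-fold higher number from compound 2 to compound 3 (0.25 log units; within the scatter) shows that, on a saturated chain carbon two bonds along the chain from an amide-type nitrogen, 3-carboxypropyl can take the place of 2-(sulfooxy)ethoxy with no difference beyond the scatter. The large step seen earlier is therefore not tied to the sulfooxy group alone, since 5-carboxypentyl in place of 1-(hydroxymethyl)ethyl on the amide-type nitrogen also gives a 14-fold lower number from compound 1 to compound 3 (1.16 log units; beyond the scatter). No available evidence explains why these two tails give such similar numbers.

On these data alone, it remains open whether the end group of the tail matters or whether the length of the chain is enough. A plain alkyl chain, an amine at the chain end or a longer chain ending in a carboxylic acid could each help to separate these possibilities.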